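One Stereocentre Inverted on a Glucuronidation Half-Life

The compounds below may be only part of what the source reports. "The series", "measured", "known", "first", "only" and "open" are said of these compounds alone.

Four compounds share a common core and side chain. Compound 1 `NS(=O)(=O)CC(=O)NCCSc1nonc1/C(=N/O)Nc1cccc(Br)c1` gives 0.955 h in an ADME assay on isolated protein for pharmacokinetics, with UDP-glucuronosyltransferase 1A9 (Homo sapiens) as the target, read by LC-MS, with a stated time of 60 min, at 37 degrees C, tested at 1 uM, in the presence of a further agent that is not named here; on this read-out higher numbers stand for a longer-lived compound and lower numbers for a shorter-lived compound. Compound 2 `C[C@H](CSc1nonc1/C(=N/O)Nc1ccc(F)c(Br)c1)NC(=O)CS(N)(=O)=O` gives 1.33 h in this assay, and its number and that of compound 1 lie within the usual scatter of each other. Compound 3 `N#Cc1cc(N/C(=N\O)c2nonc2SCCNC(=O)CS(N)(=O)=O)ccc1F` reaches > 3 h in this assay, which is a limit of the assay rather than a number (the limit of > 3 h in this assay, at which 1 of the 3 values shown sits). For the measured compounds named here, the only step measured so far, an at least 3.1-fold higher number from compound 1 to compound 3 (0.49 log units; beyond the scatter), concerns a change of the aromatic ring on the amine nitrogen and nothing else.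

Compound 4 `C[C@@H](CSc1nonc1/C(=N/O)Nc1ccc(F)c(Br)c1)NC(=O)CS(N)(=O)=O` differs from compound 2 only in this way: the two compounds have the same atoms and bonds and differ only in configuration as drawn: 1 of 2 stereo elements differ; a stereocentre at a saturated chain carbon is drawn R in compound 2 and S in compound 4. Going by the values given here, no measured step inverts a stereocentre, so the size of such a change in this assay has no direct guide here, and the one measured step touches an unrelated part of the molecule. The expectation is therefore a step within the scatter, a 1.0-fold lower number from compound 2 to compound 4 (0.01 log units; within the scatter). Compound 4 is estimated at 1.3 h, with a range from 0.6 h to 2.8 h.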

Compound 4, half-life: > 3 h
Compound 4: no number, only a limit (the forecaster's own chance of this, stated with the estimate: 10%); middle value at least 2.3-fold (0.36 log units) away from the limit.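

Drawing the saturated chain carbon S rather than R gives, in this assay, an at least 2.2-fold higher number from compound 2 to compound 4 (0.35 log units; beyond the scatter). This step can be put down to that one carbon alone, something the earlier step on the aromatic ring could not show about this part of the side chain, because of one fact: the fact that compounds 2 and 4 differ only in the configuration as drawn. Compound 4 gives > 3 h, which is a limit and not a number.

How far compound 4 lies past that limit stays open, so the full size of the step is unknown, and the compounds shown do not say whether the same inversion would matter with the 3-cyano-4-fluorophenyl ring on the amine nitrogen. Also open, on these data alone, is what an ethyl group, an amine or a carboxylic acid would do in place of the methyl group on that chain carbon.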